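Removing the ring chlorine: a step toward the unsubstituted analogue

This account rests on a few compounds, and the source may have more. Where it says the series, first, only, none or still open, it means among the compounds named here.

Measured compounds:
Compound 1, `NC(=O)c1c(NC(=O)c2ccccc2Cl)sc2c1CCN(C(=S)Nc1ccccc1)C2`, 46700 nM.
Compound 2, `NC(=O)c1c(NC(=O)c2ccccc2)sc2c1CCN(C(=S)Nc1ccccc1Cl)C2`, > 50000 nM.

In a functional assay on HeLa cells (Homo sapiens) for antiproliferative activity, with a stated time of 24 h (on this read-out lower numbers stand for stronger inhibition and higher numbers for weaker inhibition), compound 1 gives 46700 nM. For compound 2 only a limit of the assay is known, > 50000 nM, and the limit of > 50000 nM in this assay, at which 1 of the 2 values shown sits, shows that one of the two values sits there. Compound 2 therefore stands at the edge of what this assay can report, with no number beyond the limit.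

Compound 3, `NC(=O)c1c(NC(=O)c2ccccc2)sc2c1CCN(C(=S)Nc1ccccc1)C2`, is the one still to be measured. It arises from compound 2 by hydrogen in place of chloro on an aromatic carbon. Among the measured compounds shown here, no step between measured compounds is given for this change, so its size cannot be read from the data. Compound 3 is expected to stay weak, with a step of an at least 1.1-fold lower number from compound 2 to compound 3 (0.04 log units; that floor lies within the scatter) that is estimated to lie within the usual scatter rather than beyond it. Compound 3 is estimated at 45000 nM, within a range from 15000 nM to 100000 nM.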

Compound 3, half-maximal inhibitory concentration: > 50000 nM
Compound 3: only a limit was reported; the forecaster's own chance of this, stated with the estimate: 50%; middle value at least 1.1-fold (0.04 log units) away from the limit.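

In this assay compound 3 is reported only as a limit, > 50000 nM, so the analogue with neither chloro group gives no number within the range of this read-out. Taking the change as 2-chlorophenyl to phenyl on the amide side, the data show an at least 1.0-fold higher number from compound 1 to compound 3 (0.02 log units; that floor lies within the scatter), a floor that lies within the scatter, so the loss of this chloro group is not shown to matter in either direction. Compound 2 and compound 3 are both limits, and the step between them cannot be read, which leaves the other chloro group just as unresolved, with most of the series now at the edge of the read-out: the limit of > 50000 nM in this assay, at which 2 of the 3 values shown sit.

As far as these compounds go, how far compound 3 lies past its limit remains open. So does whether another group on this aromatic carbon, such as an amine or a methoxy group, would give a number within the range of this assay.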